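The source may report more compounds than this note shows. Statements on the series, on what has been measured and on what is new or still open speak of the compounds shown alone.

Working notes on the series in a functional assay on the whole organism (B cells) with Mus musculus as the target; on this read-out higher numbers stand for larger maximal responses and lower numbers for smaller maximal responses.

Of the compounds shown here, three have numbers so far. Compound 1, `Nc1nc(O)c2c(n1)n(C1OC(CO)[C@@H](O)[C@H]1O)c(=O)n2CC(O)CSc1ccccc1`, gives 12% in this assay. For the measured compounds named here, compound 3, `CCCn1c(=O)n(C2CCC(CO)O2)c2nc(NC(=O)C(C)(C)C)nc(O)c21`, gives 19%, a number within the scatter of the one for compound 1, so the two cannot be told apart on this read-out. Compound 2, `C=CCn1c(=O)n(C2OC(CO[Si](c3ccccc3)(c3ccccc3)C(C)(C)C)[C@@H](O)[C@H]2O)c2nc(N)nc(O)c21`, gives 33%, which lies beyond the scatter and higher than compound 1. Compound 1 thus stands at the low end of the three numbers, though not separated from compound 3.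

No pair of these compounds differs in a single place, so no measured step is available to guide the next change. Compound 4, `CN(C)CCCn1c(=O)n(C2OC(CO)[C@@H](O)[C@H]2O)c2nc(N)nc(O)c21`, is related to compound 1 by one change: 2-(dimethylamino)ethyl in place of 1-hydroxy-2-(phenylsulfanyl)ethyl on a saturated chain carbon bound to an aromatic nitrogen. The other chains on the same saturated carbon in compound 2 and compound 3 give numbers from the scatter of compound 1 up to a step beyond it, so for the step from compound 1 to compound 4 no change beyond the scatter is expected, with a lean toward a slightly higher number; the expected step is a number 8 percentage points higher from compound 1 to compound 4 (within the scatter). Compound 4 is estimated to give 20%, with a range from 8% to 38%.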

Compound 4, largest response reached (reported as maximal response), in percent of the reference or control that the assay uses: 83%
The estimate for compound 4 lay 63 percentage points below the measured number, outside the stated range (above it).
By their numbers in this assay, from the lowest: compounds 1 and 3 (each within the scatter of the next); then compound 2; then compound 4.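

In this assay, for the compounds shown here, the group on a saturated chain carbon bound to an aromatic nitrogen turns out to matter strongly: 2-(dimethylamino)ethyl in place of 1-hydroxy-2-(phenylsulfanyl)ethyl gives a number 71 percentage points higher from compound 1 to compound 4 (beyond the scatter), the first measured single-place step. This one change swaps a group of 10 heavy atoms, with a six-membered aromatic ring of carbon only, an oxygen and a sulfur, for a group of 5 heavy atoms with no ring and a nitrogen, so the position tolerates a large change of group and the read-out responds to it. Nothing available here bears on why the step is so large.

Going by these compounds alone, with only this one step, it remains open which part of the change carries it: the entry of the dimethylamino nitrogen, the loss of the aromatic ring, the loss of the hydroxyl or sulfur, or the smaller size of the group. Also open, on these data alone, is how a primary amine, a carboxylic acid or a longer chain ending in a dimethylamino group would read on the same saturated chain carbon.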